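The source may hold more compounds than are shown below. What is called first, only, known or untested is meant among the compounds shown, and "the series" means these compounds.

Compound 1 `Cc1ccc(CNc2nc(Nc3ccc(N4CCN(C)CC4)cn3)ncc2Cl)cc1`: 38100 nM
Compound 2 `CN1CCN(c2ccc(Nc3ncc(Cl)c(NCc4ccc(F)cc4)n3)nc2)CC1`: 19300 nM
Compound 3 `COc1ccc(CNc2nc(Nc3ccc(N4CCN(C)CC4)cn3)ncc2Cl)cc1`: 17300 nM

In a functional assay on MCF7 cells (Homo sapiens) for inhibition, read by CCK-8 assay, with a stated time of 48 h (on this read-out lower numbers stand for stronger inhibition of growth and higher numbers for weaker inhibition of growth), compound 3 gives 17300 nM. It stands within the scatter of its nearest neighbour, a 1.1-fold lower number from compound 2 to compound 3 (0.05 log units; within the scatter), and the gap to the furthest is modest, a 2.2-fold lower number from compound 1 to compound 3 (0.34 log units; beyond the scatter). Compound 4 `Cc1ccc(Nc2nc(Nc3ccc(N4CCN(C)CC4)cn3)ncc2Cl)cc1` carries 4-methylphenyl in place of 4-methoxybenzyl on a nitrogen on an aromatic ring. The measured steps only exchange a group on an aromatic carbon, the largest being a 2.2-fold lower number from compound 1 to compound 3 (0.34 log units; beyond the scatter), and the smallest a 1.1-fold lower number from compound 2 to compound 3 (0.05 log units; within the scatter). None of them tests the loss of the benzyl carbon, so they give little guidance on direction. The expected step, a 1.2-fold lower number from compound 3 to compound 4 (0.06 log units; within the scatter), is small, though uncertain. For compound 4 the estimated value is 15000 nM, with an expected range from 4000 nM to 45000 nM.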

Compound 4, concentration for 50% growth inhibition: 11400 nM
Estimate against measurement, compound 4: 1.3-fold (0.12 log units) above; the measured number falls inside the stated range.
By their numbers in this assay, from the lowest: compounds 4, 3, 2 and 1 (each within the scatter of the next, the first and the last beyond it).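

Keeping the methyl on the ring and changing only 4-methylbenzyl to 4-methylphenyl on the nitrogen gives the first comparison of this kind, a 3.3-fold lower number from compound 1 to compound 4 (0.52 log units; beyond the scatter), a modest gain in this assay. Against the other two benzyl groups the same kind of exchange stays inside the noise, with a 1.5-fold lower number from compound 3 to compound 4 (0.18 log units; within the scatter) and a 1.7-fold lower number from compound 2 to compound 4 (0.23 log units; within the scatter), so the benzyl carbon is not needed for growth inhibition in any of the three pairs. Nothing available explains these steps.

As far as these compounds go, it remains open how 4-methoxyphenyl or 4-fluorophenyl would behave on this nitrogen. From the compounds shown here alone, a longer chain before the ring, or an amine or carboxylic acid on it, also remains untested here.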